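The compounds below may be only part of what the source reports. "The series", "measured", "known", "first", "only" and "open" are said of these compounds alone.

Measured compounds:
compound 1 `O=C(O)c1cc(-n2c(-c3ccccc3)cc3c2CCCC3)ccc1O` — >= 60%
compound 2 `O=C(O)c1cc(-n2c(-c3ccccc3)cc3c2CCCC3)cc(Br)c1O` — 0%

In a functional assay on the whole organism (strain Wistar) for inhibition, with Rattus norvegicus as the target, read by paw edema, with stated times of 30 min and 3 h, at a dose of 200 mg/kg by the oral route (on this read-out higher numbers stand for more inhibition at the one dose given (going by the name of the read-out) and lower numbers for less inhibition), compound 1 gives >= 60%, which is a limit of the assay and not a number (the limit of >= 60% in this assay, at which 1 of the 2 values shown sits). Compound 2 gives 0%. The measured step is a number at least 60 percentage points lower from compound 1 to compound 2 (beyond the scatter), so the value of compound 1 is known only as a limit and that of compound 2 sits at no inhibition.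

Compound 3 `O=C(O)c1cc(-n2c(-c3ccc(Br)cc3)cc3c2CCCC3)ccc1O` differs from compound 1 by bromo in place of hydrogen on an aromatic carbon. Among the compounds with values here, the only measured step of the same kind, bromo in place of hydrogen on an aromatic carbon, is a number at least 60 percentage points lower from compound 1 to compound 2 (beyond the scatter), made at another aromatic carbon of the shared core; it is large and downward. The step for compound 3 is therefore expected in the same direction, though its size is uncertain, estimated as a number at least 25 percentage points lower from compound 1 to compound 3 (beyond the scatter). Compound 3 is expected to give about 35%, in the range 0% to 70%.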

Compound 3, a percentage reported as inhibition, in the whole organism at one dose (the size of the read-out at that dose, not a potency): 40%
Beside the measured number, compound 3's estimate is 5 percentage points below it; measured number inside the range.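

In this assay, bromo on a second site of compound 1, an aromatic carbon of the six-membered aromatic ring of carbon only, para to a large group, also gives a downward step: a number at least 20 percentage points lower from compound 1 to compound 3 (beyond the scatter). The change phenyl to 4-bromophenyl therefore lowers the reading without removing it, as compound 3 still gives 40%. The value of compound 1 is a limit and not a number, so the full size of this step stays unfixed: the limit of >= 60% in this assay, at which 1 of the 3 values shown sits.

The compounds shown leave open whether this loss is tied to bromo itself or would also follow a fluoro, a methoxy or an amine on the same carbon. They also give no reading on why the step arises, and no reading for bromo elsewhere on this ring.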